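The source may hold more compounds than are shown below. What is called first, only, known or untested is meant among the compounds shown, and "the series" means these compounds.

Four compounds that share a core are compared here in a functional assay on VCaP cells (Homo sapiens) for antiproliferative activity, read by propidium iodide staining, with a stated time of 96 h; a lower number here means a stronger inhibitor, a higher number a weaker inhibitor. Compound 1 (`CC(O)(CSc1cccc(S(F)(F)(F)(F)F)c1)C(=O)Nc1ccc([N+](=O)[O-])cc1C(F)(F)F`) gives 28800 nM, and compound 2 (`CC(O)(COc1ccc(S(F)(F)(F)(F)F)cc1)C(=O)Nc1ccc([N+](=O)[O-])cc1C(F)(F)F`) gives 26100 nM. Compound 3 (`CC(O)(COc1ccc(S(F)(F)(F)(F)F)cc1)C(=O)Nc1cccc(S(F)(F)(F)(F)F)c1`) gives 8000 nM. This is the lowest of the three numbers, and its gap to each of the other two lies beyond the scatter of repeated measurements.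

Compound 4 (`CC(O)(COc1ccc(C(F)(F)F)cc1)C(=O)Nc1cccc(S(F)(F)(F)(F)F)c1`) has not yet been measured. It differs from compound 3 in one place, on an aromatic carbon of a six-membered aromatic ring of carbon only, para to a large group: a group of 4 heavy atoms (1 carbon, 3 fluorine; no ring) in place of a group of 6 heavy atoms (5 fluorine, 1 sulfur; no ring), on an aromatic carbon. Trifluoromethyl is the group that enters there.

Going by the values given here, no measured pair of compounds shows this change or any other single change, so the data give no direct guide to its size. A modest move toward a higher number, meaning a somewhat weaker inhibitor, is expected. The estimated change is a 1.4-fold higher number from compound 3 to compound 4 (0.14 log units; within the scatter), which may prove hard to separate from the scatter. The expected value for compound 4 is 11000 nM, with an estimated range of 4500 nM to 27000 nM.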

Compound 4, half-maximal inhibitory concentration: 13300 nM
Compound 4: middle estimate off by 1.2-fold (0.08 log units), on the low side; low and high end bracket the measured number.
By their numbers in this assay, from the lowest: compounds 3, 4, 2 and 1 (each within the scatter of the next, the first and the last beyond it).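

Going by these compounds alone, compound 3 and compound 4 give the first pair here that differs in one place: on this aromatic carbon, trifluoromethyl in place of the group of 6 heavy atoms gives a 1.7-fold higher number from compound 3 to compound 4 (0.22 log units; within the scatter) and so stays within the scatter. In this assay, therefore, this pair does not separate the two groups, and the larger group is not shown to be needed at this position for a number in this range. Nothing in the data explains this result.

From the compounds shown here alone, it remains open whether a chlorine atom, a nitrile or a methoxy group on this same carbon would give a number clearly apart from these two. Going by these compounds, it also remains open whether the same exchange would give a similar step in a compound that carries a nitro group on its other ring, as compound 2 does.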